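This account rests on a few compounds, and the source may have more. Where it says the series, first, only, none or still open, it means among the compounds named here.

Of the compounds shown here, two have been measured in a functional assay on SW-620 cells (Homo sapiens) for inhibition, read by MTT assay, with a stated time of 72 h; a lower number here means a stronger inhibitor, a higher number a weaker inhibitor. Compound 2 `COc1cc(Oc2cccc(Nc3ccccc3)c2)cc(OC)c1CNCc1ccc(C)cc1` gives 11800 nM, and compound 1 `CNCc1c(OC)cc(Oc2cccc(Nc3ccccc3)c2)cc1OC` gives 15000 nM; the two values lie within the scatter of each other. Among the measured compounds shown here, the only measured step, a 1.3-fold lower number from compound 1 to compound 2 (0.10 log units; within the scatter), adds a whole aromatic group rather than swapping a substituent on one, so it bears only loosely on compound 3 `COc1cc(Oc2cccc(Nc3ccccc3)c2)cc(OC)c1CNCc1ccc(Cl)cc1`, which differs from compound 2 by chloro in place of methyl on an aromatic carbon. For the measured compounds named here, with no step of that kind measured, for compound 3 the expected step is a 1.2-fold lower number from compound 2 to compound 3 (0.07 log units; within the scatter), nothing beyond the scatter. Compound 3 is therefore estimated at 10000 nM, within 4000 nM to 25000 nM.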

Compound 3, half-maximal inhibitory concentration: 6340 nM
Estimate against measurement, compound 3: 1.6-fold (0.20 log units) above, within the range that was stated.
By their numbers in this assay, from the lowest: compounds 3, 2 and 1 (each within the scatter of the next, the first and the last beyond it).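

In this assay, chloro in place of methyl on this aromatic carbon gives a step that stays within the scatter (a 1.9-fold lower number from compound 2 to compound 3 (0.27 log units; within the scatter)), so this swap alone shows no clear effect. Among the compounds shown here, the 4-chlorophenyl group does give the first step in this set beyond the scatter, though only a modest one (a 2.4-fold lower number from compound 1 to compound 3 (0.37 log units; beyond the scatter)), which the 4-methylphenyl group did not reach. No measured evidence here offers a reason for this result. On these data alone, whether fluoro, methoxy, a nitrile or a carboxylic acid at the same place would give a larger step stays open.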